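The source may hold more compounds than are shown below. What is called first, only, known or untested is meant among the compounds shown, and "the series" means these compounds.

Measured so far:
Compound 1 `CC1CCCC(Oc2cccc3ccc(N)nc23)C1` gives 640 nM in an assay on cells with melanin-concentrating hormone receptor 1 (Homo sapiens) as the target, read by radioligand binding; a lower number here means a stronger inhibitor, a higher number a weaker inhibitor.
Compound 2 `Nc1ccc2cccc(OCCC(F)(F)F)c2n1` gives 722 nM in this assay.
Compound 3 `CC(CC(C)(C)C)Oc1cccc2ccc(N(C)C)nc12` gives only a limit in this assay, > 2000 nM, which is the limit of > 2000 nM in this assay, at which 1 of the 3 values shown sits, and not a number.

Among the two numbers shown, compound 2 has the higher one, but the gap to compound 1 lies within the scatter, so the two cannot be ordered. Compound 3 carries a different amine as well as a different chain, so it offers no single-point comparison to either.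

Compound 4 `Nc1ccc2cccc(OCC3CCC3)c2n1` differs from compound 2 in one place: cyclobutyl in place of 2,2,2-trifluoroethyl on a saturated chain carbon bound to an oxygen on an aromatic ring. Within the data shown here, no measured pair shows this kind of exchange, so the step has to be guessed from the neighbourhood. Compound 1 shows that a saturated, ring-bearing ether chain on the shared core sits near compound 2 in this assay. The step from compound 2 to compound 4 is therefore expected to be small, a 1.2-fold lower number from compound 2 to compound 4 (0.08 log units; within the scatter), not beyond the scatter in either direction. Compound 4 is expected to give about 600 nM, in a range from 250 nM to 1500 nM.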

Compound 4, half-maximal inhibitory concentration: 432 nM
For compound 4 the middle estimate is 1.4-fold (0.14 log units) above the measured one, and the stated range covers the measured number.
By their numbers in this assay, from the lowest: compounds 4, 1 and 2 (each within the scatter of the next). At a limit, above all of these: compound 3.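

Cyclobutyl in place of 2,2,2-trifluoroethyl on a saturated chain carbon bound to an oxygen on an aromatic ring gives the first one-place comparison in this assay, and it reads a 1.7-fold lower number from compound 2 to compound 4 (0.22 log units; within the scatter). At this place, then, a fluorine-bearing chain end without a ring and an all-carbon four-membered ring cannot be told apart by this read-out. Nothing shown here gives a reason for the size of this step.

On these data alone, compound 3 gives > 2000 nM, which is a limit and not a number, and it differs from the others in two places, so the part played by the amine on the shared core stays open. Also open, as far as these compounds go, is how this position answers to a very different chain end, such as a carboxylic acid or an amine.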